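The compounds below may be only part of what the source reports. "The series", "measured", "known", "first", "only" and "open" are said of these compounds alone.

In a functional assay on MGC-803 cells (Homo sapiens) for inhibition, read by MTT assay, with a stated time of 72 h (a lower number here means a stronger inhibitor, a higher number a weaker inhibitor), compound 1 `O=C(Nc1ccccc1)C1CCN(C/C=C/c2ccccc2)CC1` gives 57900 nM and compound 2 `CCCc1ccc(NC(=O)C2CCN(C/C=C/c3ccccc3)CC2)cc1` gives 5210 nM, the lower of the two numbers. Among the compounds with values here, the single measured step, an 11-fold lower number from compound 1 to compound 2 (1.05 log units; beyond the scatter), is large and goes with propyl in place of hydrogen on an aromatic carbon. Compound 3 `CC(C)c1ccc(NC(=O)C2CCN(C/C=C/c3ccccc3)CC2)cc1` alters that same group: isopropyl in place of propyl on an aromatic carbon, para to a large group. The measured step bears on this only indirectly, since it adds the chain, whereas here the same atoms are joined differently. Within the data shown here, no measured pair compares two such chains. No step beyond the scatter is therefore expected in this assay, in either direction, and compound 2 at 5210 nM remains the anchor. The expected change is a 1.1-fold higher number from compound 2 to compound 3 (0.02 log units; within the scatter). For compound 3 the estimated value is 5500 nM, with an expected range from 2600 nM to 12000 nM.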

Compound 3, half-maximal inhibitory concentration: 5200 nM
Estimate against measurement, compound 3: 1.1-fold (0.02 log units) above; the measured number falls inside the stated range.
By their numbers in this assay, from the lowest: compounds 3 and 2 (each within the scatter of the next); then compound 1.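

In this assay the ring position para to a large group does not separate the straight chain from the branched one: the step is a 1.0-fold lower number from compound 2 to compound 3 (0.00 log units; within the scatter) and so the same carbons joined differently leave the number in place. The large step from hydrogen is also not tied to the propyl chain, since isopropyl gives an 11-fold lower number from compound 1 to compound 3 (1.05 log units; beyond the scatter) and thus matches what an 11-fold lower number from compound 1 to compound 2 (1.05 log units; beyond the scatter) showed for propyl. Nothing available accounts for why the two chains match or why either differs from hydrogen.

The compounds shown leave open whether a longer chain such as butyl, or a bulkier tert-butyl group, would move the number further at this position. They also leave open whether an amine or a carboxylic acid in the same place would keep the step seen with the two chains.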